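This account rests on a few compounds, and the source may have more. Where it says the series, first, only, none or still open, it means among the compounds named here.

Notes on the series. Going by the values given here, compound 3 `S=C(N/N=C/c1ccc2ccccc2n1)Nc1cccc(Cl)c1` stands at the higher of the two numbers so far in a functional assay on HL-60 cells (Homo sapiens) for antiproliferative activity, read by sulforhodamine B assay, with a stated time of 72 h (a higher number here means a weaker inhibitor, a lower number a stronger inhibitor), where compound 3 gives 28800 nM. Compound 2 `S=C(N/N=C/c1ccc2ccccc2n1)Nc1ccc(Br)cc1` gives 27500 nM there, and the step of a 1.0-fold higher number from compound 2 to compound 3 (0.02 log units; within the scatter) shows the two aryl groups behaving alike. Compound 1 `NC(=S)N/N=C/c1ccc2ccccc2n1` gives > 100000 nM, which is a limit of the assay rather than a number (the limit of > 100000 nM in this assay, at which 1 of the 3 values shown sits). From it, the steps of an at least 3.6-fold lower number from compound 1 to compound 2 (0.56 log units; beyond the scatter) and an at least 3.4-fold lower number from compound 1 to compound 3 (0.54 log units; beyond the scatter) show that an aryl group on the amide-type nitrogen lowers the number. Compound 4 `N#Cc1ccc(NC(=S)N/N=C/c2ccc3ccccc3n2)cc1` carries 4-cyanophenyl in place of 3-chlorophenyl on an amide-type nitrogen. Among the compounds with values here, the only measured step that bears on an aryl-for-aryl exchange, a 1.0-fold higher number from compound 2 to compound 3 (0.02 log units; within the scatter), lay within the scatter, so no step beyond the scatter is expected here: a 1.0-fold lower number from compound 3 to compound 4 (0.01 log units; within the scatter). Compound 4 is therefore expected at 28000 nM, between 10000 nM and 80000 nM.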

Compound 4, half-maximal inhibitory concentration: 4660 nM
Estimate against measurement, compound 4: 6.0-fold (0.78 log units) above; measured number below the stated range.
By their numbers in this assay, from the lowest: compound 4; then compounds 2 and 3 (each within the scatter of the next). At a limit, above all of these: compound 1.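

At this position the aryl groups are not interchangeable in this assay: a 6.2-fold lower number from compound 3 to compound 4 (0.79 log units; beyond the scatter) and a 5.9-fold lower number from compound 2 to compound 4 (0.77 log units; beyond the scatter) both lie beyond the scatter, unlike a 1.0-fold higher number from compound 2 to compound 3 (0.02 log units; within the scatter). Going by these compounds alone, compound 4 therefore gives the lowest number so far, and cyano in place of bromo is the first exchange on the aromatic ring to move the number beyond the scatter. Compound 1 stands at a limit, so an at least 21-fold lower number from compound 1 to compound 4 (1.33 log units; beyond the scatter) gives only a bound: the limit of > 100000 nM in this assay, at which 1 of the 4 values shown sits.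

As far as these compounds go, whether 4-aminophenyl or 4-carboxyphenyl in place of 4-cyanophenyl on the amide-type nitrogen would give a similar number stays open. The compounds shown also do not separate the cyano group from its place on the ring.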